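This account rests on a few compounds, and the source may have more. Where it says the series, first, only, none or still open, it means among the compounds named here.

Measured so far:
- compound 1 `COc1ccc(CNc2nc3cc(N)cc(N)c3nc2-c2ccccc2)cc1OC`: 24500 nM
- compound 2 `COc1cc(CNc2nc3cc(N)cc(N)c3nc2-c2ccccc2)cc(OC)c1OC`: 8710 nM
- compound 3 `CCOC(=O)[C@H](CCC(=O)O)NC(=O)c1ccc(Oc2nc3cc(N)cc(N)c3nc2-c2ccccc2)cc1`: 8710 nM

In a functional assay on CAKI-1 cells (Homo sapiens) for inhibition, read by sulforhodamine B assay, with a stated time of 48 h (a lower number here means a stronger inhibitor of growth, a higher number a weaker inhibitor of growth), compound 1 gives 24500 nM, the highest of the three numbers. Compound 2 sits at 8710 nM. Going by the values given here, compound 3 shares no single-point step with compound 1. Compound 3 sits at 8710 nM. Both of these numbers are lower than that of compound 1.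

The next compound is compound 4 `COc1ccc(CNc2nc3cc(N)cc(N)c3nc2-c2ccccc2)cc1`, which differs from compound 1 by hydrogen in place of methoxy on an aromatic carbon.

Among the compounds with values here, one measured step bears on this: a 2.8-fold lower number from compound 1 to compound 2 (0.45 log units; beyond the scatter), where a methoxy entered and the number fell. Within the data shown here, in compound 4 a methoxy leaves instead, at a different place on the same ring, so the step is expected to run the other way and to be of about the same modest size, with wide uncertainty since only one step on this ring is known.

The expectation for compound 4 is therefore a 1.6-fold higher number from compound 1 to compound 4 (0.21 log units; within the scatter), giving an estimated 40000 nM with a range from 15000 nM to 90000 nM.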

Compound 4, concentration for total growth inhibition: 36300 nM
Compound 4: the middle estimate sits 1.1-fold (0.04 log units) above what was measured; measured number inside the range.
By their numbers in this assay, from the lowest: compounds 2 and 3 (each within the scatter of the next); then compounds 1 and 4 (each within the scatter of the next).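

In this assay, the change from 3,4-dimethoxyphenyl to 4-methoxyphenyl gives a 1.5-fold higher number from compound 1 to compound 4 (0.17 log units; within the scatter), so hydrogen and methoxy cannot be told apart on this aromatic carbon, ortho to a methoxy group. The other change on this ring, a 2.8-fold lower number from compound 1 to compound 2 (0.45 log units; beyond the scatter), lies beyond the scatter, so among these compounds only that change separates a ring pattern from the one in compound 1. No measured evidence bears on why this position gives so small a step.

Still open, on these data alone, is whether the methoxy that remains in compound 4 matters, which a plain unsubstituted phenyl would test. Also open, as far as these compounds go, is whether a hydroxyl, a fluorine or an ethoxy on this carbon would give a number clearly apart from those of compound 1 and compound 4.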